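Acetyl in place of hydrogen: compound 1 to compound 4

The source may report more compounds than this note shows. Statements on the series, on what has been measured and on what is new or still open speak of the compounds shown alone.

Compound 1 `C/C=C(\C)C(=O)O[C@H]1[C@]2(C)C[C@@H]3O[C@@]1(O)C=C1C4=CC(=O)O[C@@H](c5ccoc5)[C@]4(C)CC[C@@H]1[C@]3(C)[C@@H]2[C@@H](O)C(=O)OC` gives 8100 nM in a functional assay on A549 cells (Homo sapiens) for inhibition, read by MTT assay, with a stated time of 24 h (on this read-out higher numbers stand for weaker inhibition and lower numbers for stronger inhibition), and holds the lowest of the two numbers given here, with compound 2 nearest at a step within the scatter. Compound 2 `C/C=C(\C)C(=O)O[C@@H]1[C@]2(OC(=O)C3CC3)C=C3C4=CC(=O)O[C@@H](c5ccoc5)[C@]4(C)CC[C@@H]3[C@@]3(C)[C@H](C[C@]1(C)[C@H]3[C@@H](O)C(=O)OC)O2` gives 11800 nM, the step being a 1.5-fold higher number from compound 1 to compound 2 (0.16 log units; within the scatter). Compound 3 `C/C=C(\C)C(=O)O[C@@H]1[C@]2(OC(=O)CC)C=C3C4=CC(=O)O[C@@H](c5ccoc5)[C@]4(C)CC[C@@H]3[C@@]3(C)[C@H](C[C@]1(C)[C@H]3[C@@H](O)C(=O)OC)O2` returns only a limit, > 100000 nM, which is the limit of > 100000 nM in this assay, at which 1 of the 3 values shown sits, and not a number. From that limit follow an at least 12-fold higher number from compound 1 to compound 3 (1.09 log units; beyond the scatter) and an at least 8.4-fold higher number from compound 2 to compound 3 (0.92 log units; beyond the scatter).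

Compound 4 `C/C=C(\C)C(=O)O[C@H]1[C@]2(C)C[C@@H]3O[C@@]1(O)C=C1C4=CC(=O)O[C@@H](c5ccoc5)[C@]4(C)CC[C@@H]1[C@]3(C)[C@@H]2[C@@H](OC(C)=O)C(=O)OC` is not yet measured. It differs from compound 1 by acetyl in place of hydrogen on an oxygen on a saturated carbon. The two measured steps from compound 1 likewise swap an acyl group for that same hydrogen, so both bear on it: the cyclopropylcarbonyl step stayed within the scatter, while the propanoyl step was large and went toward a weaker inhibition. Acetyl, a small open-chain acyl group, is closer in kind to propanoyl than to cyclopropylcarbonyl, so a step toward higher numbers is expected, though its size is uncertain.

Compound 4 is estimated at 25000 nM, within 8000 nM to 100000 nM, which would be a step of a 3.1-fold higher number from compound 1 to compound 4 (0.49 log units; beyond the scatter).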

Compound 4, half-maximal inhibitory concentration: > 100000 nM
Compound 4 was reported as a limit; the forecaster's own chance of this, stated with the estimate: 25%; middle value at least 4.0-fold (0.60 log units) away from the limit.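

In this assay, going by these compounds, turning the hydroxy of the hydroxy(methoxycarbonyl)methyl group into acetoxy gives an at least 12-fold higher number from compound 1 to compound 4 (1.09 log units; beyond the scatter), and the true size of that step stays unknown, since the value of compound 4 is a limit and not a number. This is the only change shown at this hydroxy: compound 2 and compound 3 keep it free and carry their acyl groups on a different oxygen, so their steps from compound 1 did not test this position, and here a single acetyl group is enough to reach the limit. Compound 3 and compound 4 cannot be ordered against each other, and they differ in more than one place in any case: the limit of > 100000 nM in this assay, at which 2 of the 4 values shown sit.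

With acetyl as the only group shown on this oxygen, the result does not separate the loss of the free hydroxy from the presence of an acyl group. A methyl ether, a butanoyl chain or an aminoacetyl group at this oxygen would test that, and the compounds shown also leave open whether any replacement of this hydroxy keeps a value near that of compound 1.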